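This account rests on a few compounds, and the source may have more. Where it says the series, first, only, none or still open, it means among the compounds named here.

Working notes on a series built on one shared core. Compound 1 `Cc1cnc(Nc2ccc(C(C)C)cc2)nc1Nc1nc2ccccc2s1`, compound 2 `Cc1cnc(Nc2ccc([N+](=O)[O-])cc2)nc1Nc1nc2ccccc2s1` and compound 3 `Cc1cnc(Nc2ccc(S(N)(=O)=O)cc2)nc1Nc1nc2ccccc2s1` have been tested in a functional assay on MDA-MB-231 cells (Homo sapiens) for antiproliferative activity, read by MTT assay, with a stated time of 48 h; on this read-out higher numbers stand for weaker inhibition and lower numbers for stronger inhibition. Compound 1 reports only a limit of the assay, > 50000 nM, not a number. Compound 2 gives 22500 nM and compound 3 gives 16800 nM. Of the two numbers in hand, that of compound 2 sits nearest the limit, with compound 3 within the scatter of it (a 1.3-fold lower number from compound 2 to compound 3 (0.13 log units; within the scatter)). The steps from the limit are an at least 2.2-fold lower number from compound 1 to compound 2 (0.34 log units; beyond the scatter) and an at least 2.9-fold lower number from compound 1 to compound 3 (0.47 log units; beyond the scatter), both resting on (the limit of > 50000 nM in this assay, at which 1 of the 3 values shown sits).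

Compound 4 `COc1cccc(Nc2ncc(C)c(Nc3nc4ccccc4s3)n2)c1` is not yet measured. Relative to compound 2 the change is 3-methoxyphenyl in place of 4-nitrophenyl on a nitrogen on an aromatic ring. The three measured steps all exchange the substituent on the same aromatic ring, and they span from a limit down to the values of compound 2 and compound 3, with nitro and sulfamoyl indistinguishable within the scatter. Among the compounds with values here, no measured step covers a methoxy group or a change of position on that ring, so the expectation is loose. In this assay compound 4 is estimated at 30000 nM, with a range from 12000 nM to 60000 nM, which would mean a step of a 1.3-fold higher number from compound 2 to compound 4 (0.12 log units; within the scatter).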

Compound 4, half-maximal inhibitory concentration: > 50000 nM
Compound 4: only a limit was reported; the forecaster's own chance of this, stated with the estimate: 35%; at least 1.6-fold (0.22 log units) between middle value and limit.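

Putting 3-methoxyphenyl in place of 4-nitrophenyl on the nitrogen gives an at least 2.2-fold higher number from compound 2 to compound 4 (0.34 log units; beyond the scatter), so at this place on the shared core a change of aryl group can take the read-out back out of the measurable range. In this assay compound 4 reports only a limit of the assay, > 50000 nM, not a number. The step from compound 1 to compound 4 cannot be read, because both compounds end at that limit: the limit of > 50000 nM in this assay, at which 2 of the 4 values shown sit.

Methoxy and its place on the ring change together in this step, and the compounds shown do not separate the two. Also open, going by these compounds, is how an amine, a carboxylic acid or a longer chain on that ring would read out, and whether any such group would give a number clearly lower than those of compound 2 and compound 3.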